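The source may report more compounds than this note shows. Statements on the series, on what has been measured and on what is new or still open speak of the compounds shown alone.

Compound 1 `COc1cc2c(cc1N1C[C@@H](C)N[C@@H](C)C1)N(S(=O)(=O)c1ccc(-c3ccccn3)s1)CC2` gives 0.9 in a functional assay with growth hormone secretagogue receptor type 1 (Homo sapiens) as the target; a lower number here means a smaller maximal response, a higher number a larger maximal response.
Compound 2 `COc1cc2c(cc1N1CCN[C@@H](C)C1)N(S(=O)(=O)c1ccc(-c3ccccn3)s1)CC2` gives 1 in this assay.

Among these two numbers compound 2 holds the upper one, yet the step a number 0.10 higher from compound 1 to compound 2 (within the scatter) does not separate it from compound 1. Compound 3 `COc1cc2c(cc1N1CCN[C@H](C)C1)N(S(=O)(=O)c1ccc(-c3ccccn3)s1)CC2` has not been measured; it differs from compound 2 as follows: the two compounds have the same atoms and bonds and differ only in configuration as drawn: 1 of 1 stereo elements differ; a stereocentre at a saturated ring carbon is drawn S in compound 2 and R in compound 3. Among the measured compounds shown here, no measured step concerns a change of configuration alone, and the only step available, a number 0.10 higher from compound 1 to compound 2 (within the scatter), lies within the scatter, so nothing points to a shift beyond the scatter in this assay. Compound 3 is therefore expected to give about 0.95, between 0.8 and 1.05, a step of a number 0.050 lower from compound 2 to compound 3 (within the scatter).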

Compound 3, intrinsic activity: the largest response reached, as a fraction of the reference agonist's: 1
Compound 3: middle estimate off by 0.050, on the low side; the measured number falls inside the stated range.
By their numbers in this assay, from the lowest: compounds 1, 2 and 3 (each within the scatter of the next).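

In this assay, among the compounds shown here, redrawing the stereocentre at a saturated ring carbon from S to R gives no change at the digits printed from compound 2 to compound 3 (within the scatter), the first reading of configuration alone at this position. That comparison isolates a single feature: the fact that compounds 2 and 3 differ only in the configuration as drawn. Hydrogen in place of methyl on a saturated ring carbon, read once before, now gives a number 0.10 higher from compound 1 to compound 3 (within the scatter), so this change also stays within the scatter when the remaining methyl is drawn R.

Going by these compounds, whether a larger group on this ring carbon, such as ethyl or a carboxylic acid, would move the number in this assay remains open. So does the effect of hydrogen in place of both methyl groups.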